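The compounds below may be only part of what the source reports. "The series", "measured", "known", "first", "only" and "open" are said of these compounds alone.

Compound 3 `N#Cc1c(N2CCC(c3ccc(F)cc3)CC2)ccn(CC2CC2)c1=O` gives 89 nM in a functional assay on CHO cells for positive allosteric modulation of metabotropic glutamate receptor 2 (Homo sapiens), with a stated time of 30 min (a higher number here means that more compound is needed for the effect, a lower number that less compound is needed), the lowest of the three numbers measured. Compound 2 `N#Cc1c(N2CCC(c3cccc(F)c3)CC2)ccn(CC2CC2)c1=O` gives 141 nM, which lies within the scatter of compound 3, and compound 1 `CC(C)CCn1ccc(N2CCN(c3ccccn3)CC2)c(C#N)c1=O` gives 3090 nM, far higher. Compound 4 `COc1ccccc1C1CCN(c2ccn(CC3CC3)c(=O)c2C#N)CC1` differs from compound 3 by 2-methoxyphenyl in place of 4-fluorophenyl on a saturated ring carbon. Among the compounds with values here, only one measured step touches the same position: a 1.6-fold lower number from compound 2 to compound 3 (0.20 log units; within the scatter), where 4-fluorophenyl replaced 3-fluorophenyl and little changed. That step kept the same element in a new place, whereas here a methoxy group carrying one hydrogen-bond acceptor replaces the fluorine, so the outcome is less predictable. A modest change is expected, a 1.8-fold higher number from compound 3 to compound 4 (0.25 log units; within the scatter), possibly in either direction. Compound 4 is therefore estimated at 160 nM, with a range from 50 nM to 500 nM.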

Compound 4, half-maximal effective concentration: 35 nM
The estimate for compound 4 lay 4.6-fold (0.66 log units) above the measured number; measured number below the stated range.
By their numbers in this assay, from the lowest: compound 4; then compounds 3 and 2 (each within the scatter of the next); then compound 1.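

In this assay this position responds to more than the shift of a fluorine: the change to 2-methoxyphenyl gives a 2.5-fold lower number from compound 3 to compound 4 (0.41 log units; beyond the scatter) and also a 4.0-fold lower number from compound 2 to compound 4 (0.61 log units; beyond the scatter), both beyond the scatter. So this saturated ring carbon accepts a group with a hydrogen-bond acceptor, and here that group gives the lowest number so far. Nothing measured here explains the change.

Going by these compounds, compound 4 alters both the substituent and its place on the phenyl ring, so which of the two matters stays open. On these data alone, how an ethoxy group or an amine on that ring would behave is also open.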